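Methoxy on the fused benzene ring of compound 3

The compounds below may be only part of what the source reports. "The series", "measured", "known", "first", "only" and "open" are said of these compounds alone.

Three analogues share one core and differ only on a single aromatic carbon of it. Compound 1 `CCSc1nn2cc(-c3cc4ccccc4o3)nc2s1` gives in a functional assay on HEK293 cells for antagonist activity at proteinase-activated receptor 4 (Homo sapiens), read by FLIPR and calcium flux, with a stated time of 30 min (a higher number here means a weaker inhibitor, a lower number a stronger inhibitor), a value of 2900 nM. Compound 2 `CS(=O)(=O)c1nn2cc(-c3cc4ccccc4o3)nc2s1` gives in this assay 820 nM, a change of a 3.5-fold lower number from compound 1 to compound 2 (0.55 log units; beyond the scatter). Compound 3 `COc1nn2cc(-c3cc4ccccc4o3)nc2s1` gives in this assay 4 nM; the move is a 730-fold lower number from compound 1 to compound 3 (2.86 log units; beyond the scatter) and a 210-fold lower number from compound 2 to compound 3 (2.31 log units; beyond the scatter), so compound 3 stands lowest of the three, with compound 2 nearest and compound 1 furthest.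

Compound 4 `COc1nn2cc(-c3cc4c(OC)cccc4o3)nc2s1` keeps the methoxy of compound 3 on the core and adds a second one: methoxy in place of hydrogen on an aromatic carbon. None of the three measured steps touches this position; all of them exchange the group on the core, and the fused ring system is untouched throughout. For the measured compounds named here, there is therefore no measured step that bears on the change, and the expectation rests on the value of compound 3 alone. Compound 4 is expected to show a step of a 1.5-fold higher number from compound 3 to compound 4 (0.18 log units; within the scatter), nothing beyond the scatter. The estimate for compound 4 in this assay is 6 nM, with a range from 1.5 nM to 25 nM.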

Compound 4, half-maximal inhibitory concentration: 7.6 nM
Beside the measured number, compound 4's estimate is 1.3-fold (0.10 log units) below it; measured number inside the range.
By their numbers in this assay, from the lowest: compounds 3 and 4 (each within the scatter of the next); then compound 2; then compound 1.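

Methoxy in place of hydrogen, on an aromatic carbon of the six-membered aromatic ring of carbon only, gives a 1.9-fold higher number from compound 3 to compound 4 (0.28 log units; within the scatter) in this assay. For the compounds shown here, this is the first step away from the group on the shared core, and unlike the three steps on the core, which all lie beyond the scatter, it stays within the scatter. So this aromatic carbon can carry a methoxy while the number remains in the range of compound 3, but no measurement at hand explains this result.

The compounds shown leave open how an amine, a carboxylic acid or a longer alkoxy chain would read at this aromatic carbon. Also open, as far as these compounds go, is whether the same methoxy step would hold with ethylsulfanyl or methylsulfonyl on the core.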